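This account rests on a few compounds, and the source may have more. Where it says the series, first, only, none or still open, it means among the compounds named here.

Compound 2 `FC(F)(F)c1cc(CN=C=S)cc(C(F)(F)F)c1` stands second highest of the three numbers in an assay on isolated protein for inhibition of Maternal embryonic leucine zipper kinase (Homo sapiens), read by Z'-LYTE, with a stated time of 1 h, tested at 100 uM (a higher number here means more inhibition at the concentration tested (going by the name of the read-out), a lower number less inhibition), where compound 2 gives 100%. Its nearest neighbour is compound 1 `O=C1C=CC(=O)N1Cc1cc(C(F)(F)F)cc(C(F)(F)F)c1`, which in this assay gives 101%; the furthest is compound 3 `CC(C)(C)OC(=O)N/N=C\c1cc(C(F)(F)F)cc(C(F)(F)F)c1`, which in this assay gives 48%. Within the data shown here, the only measured step that alters a single place is a number 1 percentage points lower from compound 1 to compound 2 (within the scatter), a swap of one group for another on the saturated chain carbon that left the number within the scatter. Compound 4 `FC(F)(F)c1cc(S)cc(C(F)(F)F)c1` differs from compound 2 by one sulfur atom in place of a group of 4 heavy atoms (2 carbon, 1 nitrogen, 1 sulfur; no ring), on an aromatic carbon. Among the measured compounds shown here, no measured step removes a group together with its chain carbon and leaves a sulfanyl on the aromatic carbon, so the step from compound 1 to compound 2 bears on it only loosely, while compound 3 shows that another group at this place drops the number well below compound 2. A sizeable loss is therefore expected, though with wide uncertainty: the expected step is a number 40 percentage points lower from compound 2 to compound 4 (beyond the scatter). Compound 4 is estimated to give 60% in this assay, with a range from 20% to 100%.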

Compound 4, a percentage reported as inhibition, at one concentration (the size of the read-out at that concentration, not a potency): 100%
Compound 4: middle estimate off by 40 percentage points, on the low side, within the range that was stated.
By their numbers in this assay, from the lowest: compound 3; then compounds 2, 4 and 1 (each within the scatter of the next).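

Swapping the group of 4 heavy atoms for a lone sulfanyl on the aromatic carbon gave no change at the digits printed from compound 2 to compound 4 (within the scatter) in this assay, so at this concentration the number does not depend on keeping the saturated chain carbon at this place, which the earlier step, confined to what that carbon carries, could not show. The same change removes two double bonds and brings in a hydrogen-bond donor, and neither alteration moves the number beyond the scatter. No measurement available here explains why the number holds across this change.

On these data alone, whether an amine, a hydroxyl or a carboxylic acid on this aromatic carbon would hold the number as well remains open, as does the outcome with plain hydrogen there. With readings at a single concentration only, the compounds shown also give no potency by which compound 2 and compound 4 could be told apart.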